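The source may hold more compounds than are shown below. What is called first, only, known or untested is meant among the compounds shown, and "the series" means these compounds.

Compound 2 `CCCCCCCCCCCCCCCCCC1OCC(COC(=O)CCCCC[n+]2ccsc2)O1` gives 1100 nM in a functional assay (Oryctolagus cuniculus) for inhibition of platelet-activating factor receptor (Cavia porcellus) (a lower number here means a stronger inhibitor, a higher number a weaker inhibitor), the lowest of the two numbers shown. Going by the values given here, its only neighbour is compound 1 `CCCCCCCCCCCCCC1OCC(COC(=O)CCCCC[n+]2ccsc2)O1`, which in this assay gives 20000 nM; the step is an 18-fold lower number from compound 1 to compound 2 (1.26 log units; beyond the scatter), a change made far along the saturated chain, not at the charged head.

Compound 3 `CCCCCCCCCCCCCCCCCC1OCC(COCCCCCC[n+]2cscc2C)O1` differs from compound 2 in that head region: a group of 12 heavy atoms (10 carbon, 1 nitrogen, 1 sulfur; one five-membered aromatic ring with 2 hetero atoms) in place of a group of 12 heavy atoms (9 carbon, 1 nitrogen, 1 oxygen, 1 sulfur; one five-membered aromatic ring with 2 hetero atoms), on an oxygen on a saturated carbon. Among the compounds with values here, no measured step touches this part of the molecule, so the one step known, from compound 1 to compound 2, does not bear on it, and nothing in the data points in either direction. In this assay, therefore, no step beyond the scatter is expected from compound 2 to compound 3: no change at the digits printed from compound 2 to compound 3 (within the scatter). Within the data shown here, compound 3 is estimated to give 1100 nM in this assay, within a range from 250 nM to 5000 nM, the wide range reflecting that no measured step informs this change.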

Compound 3, half-maximal inhibitory concentration: 3100 nM
Compound 3: middle estimate off by 2.8-fold (0.45 log units), on the low side, and the stated range covers the measured number.
By their numbers in this assay, from the lowest: compound 2; then compound 3; then compound 1.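

In this assay the head region proves not to be silent: the swap gives a 2.8-fold higher number from compound 2 to compound 3 (0.45 log units; beyond the scatter) and so shows that the group on this oxygen on a saturated carbon has a bearing on the number, although the step is modest where the one along the saturated chain is large. Both groups carry a net charge of +1 and a five-membered aromatic ring with 2 hetero atoms, so keeping these two features does not by itself hold the number steady; the entering group has no double bond outside aromatic rings and 1 hydrogen-bond acceptor in place of 2. Nothing at hand accounts for the rise.

The swap alters several features at once, so these compounds cannot say which of them carries the step. From the compounds shown here alone, how an amide link or a pyridinium head would fare in this assay also stays open.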